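This account rests on a few compounds, and the source may have more. Where it says the series, first, only, none or still open, it means among the compounds named here.

Measured so far in a functional assay on MCF7 cells (Homo sapiens) for cytotoxicity, read by MTT assay, with a stated time of 72 h; on this read-out higher numbers stand for weaker inhibition of growth and lower numbers for stronger inhibition of growth:
- compound 1 `C[Se]c1nc(N)c2ccccc2n1`: > 100000 nM
- compound 2 `CSc1nc(NCCCCCO)c2ccccc2n1`: > 100000 nM
- compound 3 `Sc1nc(NCc2ccccc2)c2ccccc2n1`: > 100000 nM

Compound 1 `C[Se]c1nc(N)c2ccccc2n1` gives > 100000 nM in this assay, and this is a limit of the assay, not a number. Compound 2 `CSc1nc(NCCCCCO)c2ccccc2n1` likewise gives only a limit, > 100000 nM, in this assay. Compound 3 `Sc1nc(NCc2ccccc2)c2ccccc2n1` also gives only a limit, > 100000 nM, in this assay. So compound 1 stands where every measured member of the series stands: at the limit, with no numerical value to rank it against the others, as the evidence shows (the limit of > 100000 nM in this assay, at which 3 of the 3 values shown sit).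

Compound 4 `Nc1nc([SeH])nc2ccccc12` is the next member. It differs from compound 1 in one place: hydrogen in place of methyl on a selenium. Within the data shown here, no step between two measured compounds is known for this series, so there is nothing to calibrate the size of this change against, and the three values that exist are all limits.

Among the measured compounds shown here, the step from compound 1 to compound 4 in this assay is expected to be no change beyond the scatter, since there is no evidence of any member of the series reaching a measurable concentration, so a number no higher from compound 1 to compound 4 (the limit leaves the size open) is the expected step. Compound 4 is accordingly expected to give about 100000 nM in this assay, with a range from 30000 nM to 400000 nM, and most likely to be reported only as a limit again.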

Compound 4, concentration for total growth inhibition: > 100000 nM
Compound 4: no number, only a limit (the forecaster's own chance of this, stated with the estimate: 70%); the middle value sits exactly at the limit.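

The step from compound 1 to compound 4, hydrogen in place of methyl on a selenium, cannot be read, since both values in this assay are limits and not numbers: the limit of > 100000 nM in this assay, at which 4 of the 4 values shown sit.

The compounds shown leave open whether any member of the series reaches a measurable concentration for total growth inhibition in this assay, and so what size this change would have on a measurable value.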